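This account rests on a few compounds, and the source may have more. Where it says the series, first, only, none or still open, it means among the compounds named here.

Compounds measured:
Compound 1, `COc1ccc(-c2cc(/C=C/C(=O)c3ccc(OC)c(OC)c3)[nH]n2)cc1`: -57%
Compound 2, `COc1cc(-c2cc(/C=C/C(=O)c3ccc(Cl)c(Cl)c3)[nH]n2)cc(OC)c1OC`: 43%

In a functional assay on A498 cells (Homo sapiens) for cytotoxicity, read by sulforhodamine B assay, with a stated time of 48 h, tested at 10 uM (on this read-out higher numbers stand for a weaker effect at the one concentration tested and lower numbers for a stronger effect), compound 1 gives -57%, while compound 2 gives 43%. Among the compounds with values here, compound 2 therefore stands highest of the two numbers, and the gap to compound 1 lies well beyond the scatter; the two compounds differ in more than one place, so the numbers alone show only that compound 2 has the weaker effect.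

Compound 3, `COc1cc(-c2cc(/C=C/C(=O)c3ccc(F)c(F)c3)[nH]n2)cc(OC)c1OC`, is not yet measured. Its structure differs from compound 2 by 3,4-difluorophenyl in place of 3,4-dichlorophenyl on a carbonyl carbon. Within the data shown here, no measured pair shows the effect of this exchange, so compound 3 is expected to stay close to compound 2 in this assay, with a step from compound 2 to compound 3 of a number 7 percentage points higher from compound 2 to compound 3 (within the scatter) and no clear direction beyond the scatter. The estimate for compound 3 is 50%, within a range from 20% to 85%.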

Compound 3, a percentage reported as activity, at one concentration (the size of the read-out at that concentration, not a potency): -14%
Compound 3: middle estimate off by 64 percentage points, on the high side; the measured number lies below the stated range.
By their numbers in this assay, from the lowest: compound 1; then compound 3; then compound 2.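

In this assay, the step of a number 57 percentage points lower from compound 2 to compound 3 (beyond the scatter) is the first reading of a single change among these compounds, and it shows that the group on the carbonyl carbon matters to the effect at the one concentration tested. The exchange keeps the heavy-atom count, the aromatic ring, the donor and acceptor counts and the neutral charge as they were, replacing only chlorine with fluorine, yet the effect becomes clearly stronger. No measurement shown here bears on the reason for this step.

Going by these compounds, compound 1 differs from compound 3 in more than one place, so whether the step would hold with other groups elsewhere on the shared core remains open. On these data alone, how a nitrile, a trifluoromethyl or an amine would read on this ring also remains unknown.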